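This account rests on a few compounds, and the source may have more. Where it says the series, first, only, none or still open, it means among the compounds named here.

Three thiosemicarbazone-like compounds built on a shared core have been tested in a functional assay on MCF7 cells (Homo sapiens) for cytotoxicity, read by MTT assay, with a stated time of 72 h, tested at 1 uM; on this read-out lower numbers stand for less inhibition of growth and higher numbers for more inhibition of growth at the one concentration tested. Compound 1 `Cc1ccnc(/C(N)=N/NC(=S)N2CCCC2)c1` gives 49%. Compound 2 `N/C(=N\NC(=S)N1CCSCC1)c1ccccn1` gives 16.3%, and compound 3 `N/C(=N\NC(=S)N1CCOCC1)c1ccccn1` gives 14.7%. Among these three numbers compound 3 is the lowest; its nearest neighbour is compound 2, which is separated from it only by a number 1.6 percentage points lower from compound 2 to compound 3 (within the scatter), while compound 1 lies well apart from both, beyond the scatter.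

Compound 4 `Cc1ccnc(/C(N)=N/NC(=S)N2CCOCC2)c1` differs from compound 3 in one place: methyl in place of hydrogen on an aromatic carbon, on an aromatic carbon of a six-membered aromatic ring with one nitrogen. Among the compounds with values here, no measured step isolates this methyl for a comparison: compound 1 also carries the methyl, but it differs from compound 3 in the ring on the thiocarbonyl carbon as well, so its higher value cannot be assigned to the methyl alone. Within the data shown here, the only single step known, a number 1.6 percentage points lower from compound 2 to compound 3 (within the scatter), concerns a different part of the molecule and is within the scatter. The expectation is therefore tentative: a modest rise, a number 11.3 percentage points higher from compound 3 to compound 4 (beyond the scatter), is expected because compound 1 with its methyl gives 49%. Compound 4 is estimated at 26%, with a range from 8% to 50%.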

Compound 4, percent growth inhibition at one concentration: 1.22%
Beside the measured number, compound 4's estimate is 24.8 percentage points above it; measured number below the stated range.
By their numbers in this assay, from the lowest: compound 4; then compounds 3 and 2 (each within the scatter of the next); then compound 1.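

In this assay, methyl in place of hydrogen on the aromatic carbon opposite the ring nitrogen gives a number 13.5 percentage points lower from compound 3 to compound 4 (beyond the scatter), so this position responds to the addition of a single carbon, and the number falls rather than rises. With the methyl present in both compounds, morpholin-4-yl in place of pyrrolidin-1-yl on the thiocarbonyl carbon gives a number 47.8 percentage points lower from compound 1 to compound 4 (beyond the scatter), a large step that ties the high number of compound 1 to its pyrrolidin-1-yl ring and not to its methyl. Nothing measured here explains either step.

Still open, from the compounds shown here alone, is whether the methyl lowers the number in the same way when pyrrolidin-1-yl or thiomorpholin-4-yl sits on the thiocarbonyl carbon. Also open, going by these compounds, is how an ethyl, a methoxy or an amine at this position would compare with the methyl.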